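The compounds below may be only part of what the source reports. "The series", "measured", "known", "first", "only" and "open" are said of these compounds alone.

Measured so far:
compound 1 `O=C(O)c1cc(-c2cccc(COc3ccc4c(c3)CN(c3ccccc3)C4=O)c2)ccc1Cl`: 260 nM
compound 2 `Cc1c(OCc2cccc(-c3ccc(Cl)c(C(=O)O)c3)c2)cc2c(c1C)C(=O)C(C1CCCC1)C2`: 180 nM

In an assay on HEK293 cells for positive allosteric modulation of metabotropic glutamate receptor 2 (Rattus norvegicus), read by thallium flux (on this read-out lower numbers stand for an effect already at smaller amounts and higher numbers for an effect only at larger amounts of compound), compound 1 gives 260 nM and stands at the top of the two numbers, yet the gap to compound 2, which gives 180 nM, lies within the usual scatter, so no order is claimed. Going by the values given here, no single-point step between measured compounds exists in this assay. Compound 3 `CC(C)CCN1Cc2cc(OCc3cccc(-c4ccc(Cl)c(C(=O)O)c4)c3)ccc2C1=O` differs from compound 1 thus: isopentyl in place of phenyl on an amide-type nitrogen in a ring. Without a comparable step to go by, a step from compound 1 to compound 3 no larger than the scatter is expected in this assay, in either direction. Compound 3 is expected to give 300 nM in this assay, with a range from 90 nM to 1000 nM. That estimate means an expected step of a 1.2-fold higher number from compound 1 to compound 3 (0.06 log units; within the scatter).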

Compound 3, half-maximal effective concentration: 60 nM
For compound 3 the middle estimate is 5.0-fold (0.70 log units) above the measured one, and the stated range ends above it.
By their numbers in this assay, from the lowest: compound 3; then compounds 2 and 1 (each within the scatter of the next).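

Isopentyl in place of phenyl on an amide-type nitrogen in a ring gives a 4.3-fold lower number from compound 1 to compound 3 (0.64 log units; beyond the scatter) in this assay, a step beyond the scatter. This position therefore responds to its substituent, and an aromatic ring of carbon is not required there for a lower number, though this rests on one pair. Open, as far as these compounds go, is how a shorter or longer chain, a cyclohexyl ring or a chain ending in an amine would read at this nitrogen. No measurement shown bears on why the number falls.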